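The compounds below may be only part of what the source reports. "The series", "measured", "known", "first", "only" and "open" are said of these compounds alone.

Compound 1, `O=C(CSc1nc(Nc2ccccc2)c2ccccc2n1)Nc1ccc(Cl)cc1`: in a functional assay on MGC-803 cells (Homo sapiens) for inhibition, read by MTT assay, with a stated time of 72 h (on this read-out higher numbers stand for weaker inhibition and lower numbers for stronger inhibition), compound 1 gives 40400 nM.
Compound 2, `O=C(CSc1nc(Nc2ccccc2)c2ccccc2n1)Nc1ccc(Br)cc1`: in this assay compound 2 gives 19300 nM.
Compound 3, `C=CC(=O)Nc1cccc(NC(=O)CSc2nc(Nc3ccccc3Cl)c3ccccc3n2)c1`: in this assay compound 3 gives 20700 nM.

Compound 1 and compound 2 share one core and differ in a single place: bromo in place of chloro on an aromatic carbon. That exchange produced a 2.1-fold lower number from compound 1 to compound 2 (0.32 log units; beyond the scatter), a step that is modest but does lie beyond the usual scatter of repeated measurements. Compound 3 is built on a different core; the difference between the core of compound 1 and the core of compound 3 is not broken down here. Compared with compound 2, compound 3 gives a number that lies within the scatter, so the two cannot be told apart on this read-out.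

Compound 4, `C=CC(=O)Nc1cccc(NC(=O)CSc2nc(Nc3ccccc3Br)c3ccccc3n2)c1`, has not yet been measured. It differs from compound 3 by bromo in place of chloro on an aromatic carbon. Within the data shown here, this is the same kind of change as the one from compound 1 to compound 2, but not the same: there the halogen sits para to a large group, here it sits ortho to a large group.

The expectation for compound 4 is a step of a 1.6-fold lower number from compound 3 to compound 4 (0.20 log units; within the scatter), resting on compound 3 at 20700 nM and on the earlier exchange, which gave a 2.1-fold lower number from compound 1 to compound 2 (0.32 log units; beyond the scatter), softened slightly because a 2.1-fold lower number from compound 1 to compound 2 (0.32 log units; beyond the scatter) was measured with the halogen para to a large group, whereas in compound 4 it sits ortho to a large group. For compound 4 the estimated value is 13000 nM, with a likely range from 5000 nM to 35000 nM.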

Compound 4, half-maximal inhibitory concentration: 12800 nM
Compound 4: middle estimate off by 1.0-fold (0.01 log units), on the high side, and the stated range covers the measured number.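

In this assay, bromo in place of chloro gives a 1.6-fold lower number from compound 3 to compound 4 (0.21 log units; within the scatter), so this step on its own cannot be told apart from the ordinary variation between repeated measurements. Set beside the earlier exchange on the other core, the new step points the same way and cannot be separated from it in size, which fits the change carrying over between the two cores even though the halogen here sits ortho to a large group: the same change on two cores in this assay, a 2.1-fold lower number (0.32 log units; beyond the scatter) from compound 1 to compound 2 and a 1.6-fold lower number (0.21 log units; within the scatter) from compound 3 to compound 4, 1.3-fold (0.11 log units) apart, within the scatter of two such steps This does not show that bromo reliably gives stronger inhibition than chloro across the series, since it rests on only two pairs of compounds and one of the two steps lies within the scatter, and it says nothing about why the numbers fall as they do.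

The compounds shown leave open whether the trend would continue along the halogens, with fluoro or iodo at the same place, or whether a non-halogen group such as methyl or methoxy would do as well. They also leave open how much the acrylamide contributes, which a compound carrying a plain propanamide in its place could help to answer.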